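Two Aryl Swaps on One Permeable Scaffold

This account rests on a few compounds, and the source may have more. Where it says the series, first, only, none or still open, it means among the compounds named here.

Of the compounds shown here, three share a core and have been measured in an ADME assay for permeability, using PAMPA, with a stated time of 30 min, at pH 7.4; on this read-out lower numbers stand for lower permeability and higher numbers for higher permeability. Compound 1 `COc1ccc(F)cc1CNCCCNc1ccnc2cc(Cc3ccc(C#N)cc3)ccc12` gives 23 10^-6 cm/s in this assay. Compound 2 `COc1ccc(F)cc1CNCCCNc1ccnc2cc(Cc3cccc(C(F)(F)F)c3)ccc12` gives 23 10^-6 cm/s, and compound 3 `N#Cc1ccc(Cc2ccc3c(NCCCNCc4ccco4)ccnc3c2)cc1` gives 23 10^-6 cm/s. The change from compound 1 to compound 2, namely (3-(trifluoromethyl)phenyl in place of 4-cyanophenyl on a saturated chain carbon bound to an aromatic carbon), gave no change at the digits printed from compound 1 to compound 2 (within the scatter). The change from compound 1 to compound 3, (furan-2-yl in place of 5-fluoro-2-methoxyphenyl on a saturated chain carbon bound to an amine nitrogen), is the difference between the two cores, and it gave no change at the digits printed from compound 1 to compound 3 (within the scatter).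

Compound 4 `FC(F)(F)c1cccc(Cc2ccc3c(NCCCNCc4ccco4)ccnc3c2)c1` has not yet been measured. It differs from compound 3 by 3-(trifluoromethyl)phenyl in place of 4-cyanophenyl on a saturated chain carbon bound to an aromatic carbon, which is the same change as that from compound 1 to compound 2, made at the same place. The two cores differ as set out in the change from compound 1 to compound 3.

From compound 3 to compound 4 the step is expected to be no change at the digits printed from compound 3 to compound 4 (within the scatter), because the same change gave no change at the digits printed from compound 1 to compound 2 (within the scatter) on the other core. In this assay compound 4 is therefore expected to give about 23 10^-6 cm/s, with a likely range from 12 10^-6 cm/s to 46 10^-6 cm/s.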

Compound 4, apparent permeability: 23 10^-6 cm/s
Compound 4: the middle estimate sits on the measured number at the digits printed, within the range that was stated.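

In this assay the new measurement gave no change at the digits printed from compound 3 to compound 4 (within the scatter) and this matches the same swap of 4-cyanophenyl for 3-(trifluoromethyl)phenyl on the other core: the same change on two cores in this assay, no change at the digits printed (within the scatter) from compound 1 to compound 2 and no change at the digits printed (within the scatter) from compound 3 to compound 4, 1.0-fold (0.00 log units) apart, within the scatter of two such steps. The swap of 5-fluoro-2-methoxyphenyl for furan-2-yl gave no change at the digits printed from compound 2 to compound 4 (within the scatter) and this also matches its earlier step: the same change on two cores in this assay, no change at the digits printed (within the scatter) from compound 1 to compound 3 and no change at the digits printed (within the scatter) from compound 2 to compound 4, 1.0-fold (0.00 log units) apart, within the scatter of two such steps. Within these four compounds, each change therefore carries from one core to the other without a shift beyond the scatter, but since every step here is flat, this does not show that a change with a real effect on the read-out would carry across in the same way.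

As far as these compounds go, whether a carboxylic acid or an amine in place of 3-(trifluoromethyl)phenyl, or a longer chain, would move the read-out remains open. So does whether these two changes would stay equally flat on any read-out other than this assay.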